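A few compounds are considered here, and "the series" means these few. Any claim that something is new, unique, unknown or untested is made for them only; others in the source may bear on it.

The measured compounds:

Compound 1, `CCCCOc1c(-c2cc(OC)c(OC)c(OC)c2)oc2ccccc2c1=O`: in a functional assay on DU-145 cells (Homo sapiens) for antiproliferative activity, read by WST assay, with a stated time of 3 days (on this read-out lower numbers stand for stronger inhibition and higher numbers for weaker inhibition), compound 1 gives > 50000 nM, which is a limit of the assay and not a number.
Compound 2, `CCN(CC)CCCOc1c(-c2cc(OC)c(OC)c(OC)c2)oc2ccccc2c1=O`: in this assay compound 2 gives > 50000 nM, again a limit of the assay.
Compound 3, `CCCN(CCC)CCCCOc1c(-c2cc(OC)c(OC)c(OC)c2)oc2ccccc2c1=O`: in this assay compound 3 gives 35800 nM.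

Compound 2 therefore stands at the limit, as compound 1 does, and only compound 3 has a measured number. The unmeasured compound 4, `CCCCCN(CCCCC)CCCCOc1c(-c2cc(OC)c(OC)c(OC)c2)oc2ccccc2c1=O`, differs from compound 2 in one place: (dipentylamino)methyl in place of diethylamino on a saturated chain carbon, three bonds along the chain from an oxygen on an aromatic ring. The most direct guide is an at least 1.3-fold lower number from compound 2 to compound 3 (0.14 log units; that floor lies within the scatter), a step of the same kind but with shorter amine arms. The step of an at least 1.3-fold lower number from compound 1 to compound 3 (0.14 log units; that floor lies within the scatter) points the same way, while a step that the two limits leave unreadable from compound 1 to compound 2. From the compounds shown here alone, both readable steps are only floors because two of the three values sit at the limit of > 50000 nM in this assay, at which 2 of the 3 values shown sit, so their true size is unknown. Lengthening the amine arms further, as in compound 4, has no measured counterpart here. Compound 4 is expected to land near compound 3, perhaps somewhat lower, and is estimated at 25000 nM, within 8000 nM to 50000 nM. That estimate means an expected step of an at least 2.0-fold lower number from compound 2 to compound 4 (0.30 log units; that floor lies within the scatter), with a real chance that this assay again reports only a limit.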

Compound 4, half-maximal inhibitory concentration: 12500 nM
The estimate for compound 4 lay 2.0-fold (0.30 log units) above the measured number; the measured number falls inside the stated range.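

In this assay, the step that compares two true numbers is a 2.9-fold lower number from compound 3 to compound 4 (0.46 log units; beyond the scatter), and it lies beyond the scatter: with dipentylamino in place of dipropylamino on the same chain, inhibition of the cells is stronger, so the length of the amine arms matters at this position. The comparisons with the two weakest-reading compounds now also clear the scatter, at an at least 4.0-fold lower number from compound 2 to compound 4 (0.60 log units; beyond the scatter) and an at least 4.0-fold lower number from compound 1 to compound 4 (0.60 log units; beyond the scatter), whereas the earlier floors reaching compound 3 did not. These last two steps give only a smallest possible size, because their starting values are limits of the assay and not numbers: the limit of > 50000 nM in this assay, at which 2 of the 4 values shown sit.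

From the compounds shown here alone, two measured numbers cannot fix a trend, so it remains open whether still longer arms, such as dihexylamino or dioctylamino, would lower the number further or whether the gain would stop. Going by these compounds, it is equally open whether the length of the arms is what counts, or whether a ring amine such as piperidine or morpholine, carried on the same chain, would do as well as dipentylamino.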